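Moving the Thiophene Attachment Point on Two Cores

A few compounds are considered here, and "the series" means these few. Any claim that something is new, unique, unknown or untested is made for them only; others in the source may bear on it.

Compound 1 `CCCOC(=O)C1=C(C)NC(=O)NC1c1cccs1` and compound 2 `CCCOC(=O)C1=C(C)NC(=O)NC1c1ccsc1` share one core, while compound 3 `COC(=O)C1=C(C)N(C)C(=O)NC1c1cccs1` and compound 4 `COC(=O)C1=C(C)N(C)C(=O)NC1c1ccsc1` share another; the difference between the two cores is not broken down here. In an assay on membranes from HeLa cells for displacement of a labelled ligand from adenosine receptor A3 (Homo sapiens), read by scintillation counting, with a stated time of 180 min, tested at 1 uM (a higher number here means more inhibition at the concentration tested (going by the name of the read-out), a lower number less inhibition), compound 1 gives 32%. Compound 2 gives 6% in this assay, and the change thiophen-3-yl in place of thiophen-2-yl on a saturated ring carbon made a step of a number 26 percentage points lower from compound 1 to compound 2 (beyond the scatter). Compound 3 gives 15% in this assay; this lies within the scatter of compound 2 and is lower than compound 1 by a margin beyond the scatter.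

Compound 4 differs from compound 3 by thiophen-3-yl in place of thiophen-2-yl on a saturated ring carbon. This is the same kind of change as that from compound 1 to compound 2, but the surroundings differ: in compound 3 the saturated ring carbon is next to the ring atom that bears a methoxycarbonyl group, whereas in compound 1 it is next to the ring atom that bears a propoxycarbonyl group, and the place in compound 3 is further described as three ring bonds from the ring atom that bears a methyl group. Because compound 3 starts lower at 15% than compound 1, a downward step of the full earlier size would run past zero inhibition, so the step for compound 4 is expected to be smaller, estimated at a number 15 percentage points lower from compound 3 to compound 4 (beyond the scatter). Compound 4 is therefore expected to show about 0% in this assay, with the estimate ranging from -15% to 12%.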

Compound 4, a percentage reported as inhibition, at one concentration (the size of the read-out at that concentration, not a potency): 22%
Beside the measured number, compound 4's estimate is 22 percentage points below it, and the stated range ends below it.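

In this assay, thiophen-3-yl in place of thiophen-2-yl on the core of compound 3 gave a number 7 percentage points higher from compound 3 to compound 4 (within the scatter) and did not repeat the clear loss seen on the core of compound 1, so the two results differ: the same change on two cores in this assay, a number 26 percentage points lower (beyond the scatter) from compound 1 to compound 2 and a number 7 percentage points higher (within the scatter) from compound 3 to compound 4, 33 percentage points apart, beyond the scatter of two such steps. In this series, then, the effect of this change did not carry from one core to the other, and the step measured on one core was a poor guide to the step on the other. This does not show which feature of the two cores accounts for the gap, as no pair shown separates those features, and two pairs tested at a single concentration say nothing about potency or about how the change would behave on any other core.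

The compounds shown leave open whether the same thiophene change would follow either pattern on a core carrying an ethoxycarbonyl group, or a carboxylic acid in place of the ester. They also leave open whether a furan-2-yl and furan-3-yl pair on the saturated ring carbon would show a similar dependence on the core.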